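From 3-methylthiophen-2-yl to 3-methoxyphenyl on the chain

A few compounds are considered here, and "the series" means these few. Any claim that something is new, unique, unknown or untested is made for them only; others in the source may bear on it.

Measured so far in a functional assay on A549 cells (Homo sapiens) for cytotoxicity; on this read-out higher numbers stand for weaker inhibition and lower numbers for stronger inhibition:
- compound 1 `C=C/C=C\[C@H](C)[C@H](OC(N)=O)[C@@H](C)[C@H](O)[C@@H](C)C/C(C)=C\[C@H](C)[C@@H](O)[C@@H](C)/C=C\CCc1cc(F)cc(F)c1`: 1000 nM
- compound 2 `C=C/C=C\[C@H](C)[C@H](OC(N)=O)[C@@H](C)[C@H](O)[C@@H](C)C/C(C)=C\[C@H](C)[C@@H](O)[C@@H](C)/C=C\CCc1sccc1C`: 790 nM

Not yet measured: compound 3 `C=C/C=C\[C@H](C)[C@H](OC(N)=O)[C@@H](C)[C@H](O)[C@@H](C)C/C(C)=C\[C@H](C)[C@@H](O)[C@@H](C)/C=C\CCc1cccc(OC)c1`.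

For the measured compounds named here, only two numbers are available, and they cannot be told apart. Going by the values given here, the single measured step is a 1.3-fold lower number from compound 1 to compound 2 (0.10 log units; within the scatter), so compound 2 at 790 nM holds no real separation from its only neighbour.

The next change is 3-methoxyphenyl in place of 3-methylthiophen-2-yl on a saturated chain carbon, two bonds along the chain from a double-bonded chain carbon. In words, 3-methoxyphenyl takes the place of 3-methylthiophen-2-yl on a saturated chain carbon, two bonds along the chain from a double-bonded chain carbon. The measured step bears directly on this, as it exchanged one aromatic group for another at the same place and stayed inside the scatter. Among the compounds with values here, one step is thin evidence, and no measured compound carries a methoxy group, so the range is kept wide. No shift beyond the scatter is expected in this assay, in either direction. The expected step is a 1.1-fold higher number from compound 2 to compound 3 (0.06 log units; within the scatter). Compound 3 is estimated at 900 nM, with an expected range of 350 nM to 2300 nM.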

Compound 3, half-maximal inhibitory concentration: 600 nM
Estimate against measurement, compound 3: 1.5-fold (0.18 log units) above; measured number inside the range.
By their numbers in this assay, from the lowest: compounds 3, 2 and 1 (each within the scatter of the next).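

In this assay, replacing the five-membered aromatic ring of 3-methylthiophen-2-yl with the six-membered carbon ring of 3-methoxyphenyl gives a 1.3-fold lower number from compound 2 to compound 3 (0.12 log units; within the scatter), so neither the change of ring size nor the move from a sulfur-containing ring to a methoxy-bearing carbon ring separates the two compounds at this place on the chain. For the compounds shown here, the pair with the largest gap among the three, 3,5-difluorophenyl against 3-methoxyphenyl, gives a 1.7-fold lower number from compound 1 to compound 3 (0.22 log units; within the scatter), which means that all three aromatic end groups now read alike in this assay, a wider basis than the single earlier step offered. Nothing on hand explains this flat reading.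

The compounds shown all carry an aromatic ring at the end of the 4-arylbut-1-en-1-yl chain, so it remains open whether a cyclohexyl group in place of that ring, an amine or a carboxylic acid on the ring, or a longer chain would move the number beyond the scatter. From the compounds shown here alone, whether the same flat reading holds in any other cell line also remains open, as the comparison rests on this assay alone.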